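A few compounds are considered here, and "the series" means these few. Any claim that something is new, unique, unknown or untested is made for them only; others in the source may bear on it.

Measured so far:

Compound 1, `CN(C)CCNC(=O)c1c(O)c2cccnc2n(-c2ccccc2)c1=O`, gives 18.4% in a functional assay on the whole organism for inhibition, with Rattus norvegicus as the target, read by cytopathic effect and paw edema, at a dose of 100 mg/kg by the oral route; on this read-out higher numbers stand for more inhibition at the one dose given (going by the name of the read-out) and lower numbers for less inhibition.
Compound 2, `COc1ccc(NC(=O)c2c(O)c3cccnc3n(-c3ccccc3)c2=O)cc1`, gives -1.9% in this assay.

Among the compounds with values here, compound 2 is the lower of the two numbers in this assay, and the gap to compound 1 lies beyond the scatter: the one measured step is a number 20.3 percentage points lower from compound 1 to compound 2 (beyond the scatter), with 4-methoxyphenyl in place of 2-(dimethylamino)ethyl on an amide-type nitrogen.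

Compound 3, `O=C(Nc1ccc([N+](=O)[O-])cc1)c1c(O)c2cccnc2n(-c2ccccc2)c1=O`, is not yet measured in this assay. Its change from compound 2 is nitro in place of methoxy on an aromatic carbon. Within the data shown here, the only measured step concerns the exchange of the whole group on the amide-type nitrogen, not a change on the aromatic ring of that group, so nothing measured bears directly on the methoxy to nitro exchange. Among the measured compounds shown here, with compound 2 already at the bottom of the two numbers and no step of the same kind to go by, the expectation for compound 3 is a step of a number 3.9 percentage points higher from compound 2 to compound 3 (within the scatter), that is, none beyond the scatter. The estimate for compound 3 in this assay is 2%, with a range from -14% to 18%.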

Compound 3, a percentage reported as inhibition, in the whole organism at one dose (the size of the read-out at that dose, not a potency): -25.8%
Compound 3: middle estimate off by 27.8 percentage points, on the high side, and the stated range ends above it.
By their numbers in this assay, from the lowest: compound 3; then compound 2; then compound 1.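

Within the data shown here, this is the first reading of a change on the aromatic ring of the amide substituent rather than of the whole group: in this assay, nitro in place of methoxy on an aromatic carbon, para to a large group, gives a number 23.9 percentage points lower from compound 2 to compound 3 (beyond the scatter), so this position does move the read-out. Against the 2-(dimethylamino)ethyl amide, the 4-nitrophenyl group gives a number 44.2 percentage points lower from compound 1 to compound 3 (beyond the scatter), and with the earlier step this shows that the outcome for an aryl amide depends on what the ring carries, not only on a phenyl ring being present on the amide-type nitrogen. Nothing available explains why the number moves with this change.

Going by these compounds, with only methoxy and nitro at this place, it remains open whether the numbers for other groups there, such as an amine or a carboxylic acid, would lie near compound 2, near compound 3 or elsewhere. On these data alone, on the amide-type nitrogen, it also remains open whether a longer chain ending in dimethylamino, or a piperidine in its place, would raise the number above that of compound 1.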